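Second-position substituents on the chlorinated piperidine sulfonamide core

The source may report more compounds than this note shows. Statements on the series, on what has been measured and on what is new or still open speak of the compounds shown alone.

Growth inhibition in a functional assay on A2780 cells (Homo sapiens) for antiproliferative activity, read by sulforhodamine B assay, with a stated time of 48 h; on this read-out higher numbers stand for weaker inhibition of growth and lower numbers for stronger inhibition of growth:
- compound 1 `Cc1ccc(S(=O)(=O)N2CCC(Cl)CC2)cc1`: only the limit > 100000 nM; this is a limit of the assay, not a number the limit of > 100000 nM in this assay, at which 1 of the 3 values shown sits.
- compound 2 `Cc1ccc(S(=O)(=O)N2CC[C@@H](Cl)C[C@@H]2CC(C)C)cc1`: 36000 nM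
- compound 3 `Cc1ccc(S(=O)(=O)N2CC[C@@H](Cl)C[C@@H]2C2CCCCC2)cc1`: 72000 nM

Compound 3 stands beside compound 2, the step of a 2.0-fold higher number from compound 2 to compound 3 (0.30 log units; within the scatter) falling within the scatter, and the step of an at least 1.3-fold lower number from compound 1 to compound 3 (0.14 log units; that floor lies within the scatter) has a floor that also lies within the scatter. Compound 4 `Cc1ccc(S(=O)(=O)N2CC[C@@H](Cl)C[C@@H]2c2ccccc2)cc1` differs from compound 3 by phenyl in place of cyclohexyl on a saturated ring carbon. Both steps that bear on this place, a 2.0-fold higher number from compound 2 to compound 3 (0.30 log units; within the scatter) and an at least 2.7-fold lower number from compound 1 to compound 2 (0.44 log units; beyond the scatter), show the core tolerates a range of groups there without a large shift. No step beyond the scatter is therefore expected, a 1.3-fold lower number from compound 3 to compound 4 (0.12 log units; within the scatter). Compound 4 is estimated at 55000 nM in this assay, with a range from 20000 nM to 150000 nM.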

Compound 4, concentration for 50% growth inhibition: > 100000 nM
Compound 4: no number, only a limit; the forecaster's own chance of this, stated with the estimate: 30%; middle value at least 1.8-fold (0.25 log units) from the limit.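

Phenyl in place of isobutyl gives an at least 2.7-fold higher number from compound 2 to compound 4 (0.44 log units; beyond the scatter) and is the first readable loss at this position, while phenyl in place of cyclohexyl gives an at least 1.3-fold higher number from compound 3 to compound 4 (0.14 log units; that floor lies within the scatter) and stays unresolved. The step between compound 1 and compound 4 cannot be read, since both carry only limits. In this assay compound 4 gives a limit and not a number: the limit of > 100000 nM in this assay, at which 2 of the 4 values shown sit.

Going by these compounds, whether an aminomethyl group, a carboxylic acid or a chain longer than isobutyl on this saturated ring carbon would give stronger growth inhibition than compound 2 stays open.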